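The source may report more compounds than this note shows. Statements on the series, on what has been measured and on what is new or still open speak of the compounds shown alone.

Of the compounds shown here, three built on the same core have been measured in an assay on a protein complex (Cavia porcellus) with sulfonylurea receptors; K-ATP channels (Homo sapiens) as the target; on this read-out higher numbers stand for weaker inhibition and lower numbers for stronger inhibition. Compound 1 `CC(O)(C(=O)Nc1ccc(-c2nn[nH]n2)cc1)C(F)(F)F` carries a 2H-tetrazol-5-yl group on an aromatic carbon of its core. In this assay compound 1 gives only a limit, > 30000 nM, so no number is known for it. For the measured compounds named here, this is the one value that sits at the limit of > 30000 nM in this assay, at which 1 of the 3 values shown sits. Compound 2 `CCCN(CCC)S(=O)(=O)c1ccc(NC(=O)C(C)(O)C(F)(F)F)cc1` and compound 3 `CC(O)(C(=O)Nc1ccc(S(=O)(=O)N2CCOCC2)cc1)C(F)(F)F` carry sulfonyl groups instead. In this assay compound 2 gives 6440 nM. Compound 3 gives 5850 nM, and the step of a 1.1-fold lower number from compound 2 to compound 3 (0.04 log units; within the scatter) shows that exchanging the amine on the sulfonyl sulfur changes nothing beyond the scatter.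

Compound 4 `CC(O)(C(=O)Nc1ccc(Sc2ccccc2)cc1)C(F)(F)F` is not yet measured. It differs from compound 1 by phenylsulfanyl in place of 2H-tetrazol-5-yl on an aromatic carbon. Going by the values given here, no measured step covers this exchange; the only measured step, a 1.1-fold lower number from compound 2 to compound 3 (0.04 log units; within the scatter), concerns a different place. What the numbers do show is that compound 2 and compound 3, both without the tetrazole, give measurable values, while compound 1 stays beyond the limit. Compound 4 is therefore expected to fall near those two measurable values, an expected step of an at least 7.5-fold lower number from compound 1 to compound 4 (0.87 log units; beyond the scatter). The estimate for compound 4 is 4000 nM, with a range from 800 nM to 20000 nM.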

Compound 4, half-maximal inhibitory concentration: > 30000 nM
Compound 4 was reported as a limit; the forecaster's own chance of this, stated with the estimate: 10%; middle value at least 7.5-fold (0.87 log units) away from the limit.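

In this assay compound 4 gives > 30000 nM, which is a limit and not a number. Compound 1 is also a limit, so no step between compound 1 and compound 4 can be read: the limit of > 30000 nM in this assay, at which 2 of the 4 values shown sit.

The compounds shown leave open whether phenylsulfanyl or 2H-tetrazol-5-yl on the shared core gives the stronger inhibition.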